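Triazole aryl swap: compound 3 next to inactive pair

This account rests on a few compounds, and the source may have more. Where it says the series, first, only, none or still open, it means among the compounds named here.

Compound 1 `N#CC1=C(N)Oc2c(c3nc4ccccc4nc3c3ccccc23)C12C(=O)N(Cc1cnnn1-c1ccc(F)cc1)c1ccccc12` in a functional assay on HCT-116 cells (Homo sapiens) for antiproliferative activity, read by MTT assay, with a stated time of 48 h (on this read-out lower numbers stand for stronger inhibition and higher numbers for weaker inhibition), gives > 50000 nM, a limit of the assay.
Compound 2 `CCOc1ccccc1-n1nncc1CN1C(=O)C2(C(C#N)=C(N)Oc3c2c2nc4ccccc4nc2c2ccccc32)c2ccccc21` in this assay gives > 50000 nM, also a limit of the assay.

Compound 2 therefore stands only at a limit, and both shown values sit at that same limit (the limit of > 50000 nM in this assay, at which 2 of the 2 values shown sit). For the measured compounds named here, the one measured step, a step that the two limits leave unreadable from compound 1 to compound 2, cannot be read in size. Compound 3 `N#CC1=C(N)Oc2c(c3nc4ccccc4nc3c3ccccc23)C12C(=O)N(Cc1cnnn1-c1ccc(N)cc1)c1ccccc12` differs from compound 2 by 4-aminophenyl in place of 2-ethoxyphenyl on an aromatic nitrogen. With a step that the two limits leave unreadable from compound 1 to compound 2 unreadable, no step beyond the scatter in this assay is expected in either direction. Compound 3 is thus expected near 60000 nM, within 20000 nM to 200000 nM. The expected step that the limit leaves unreadable from compound 2 to compound 3 is estimated to lie within the scatter.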

Compound 3, half-maximal inhibitory concentration: 45200 nM
Compound 3: middle estimate off by 1.3-fold (0.12 log units), on the high side; the measured number falls inside the stated range.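

For the compounds shown here, compound 3 gives the first actual number at this aromatic nitrogen in this assay, so 4-aminophenyl provides a reference value that the earlier compounds did not. Going by these compounds, the changes are readable only as floors, an at least 1.1-fold lower number from compound 2 to compound 3 (0.04 log units; that floor lies within the scatter) and an at least 1.1-fold lower number from compound 1 to compound 3 (0.04 log units; that floor lies within the scatter), so their true sizes remain unknown and neither floor shows a change beyond the scatter. The other compounds remain at a limit of the assay: the limit of > 50000 nM in this assay, at which 2 of the 3 values shown sit.

Still open, on these data alone, is whether a 4-hydroxyphenyl or 4-carboxyphenyl group on this nitrogen would give a value beyond the scatter from compound 3.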